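An Amide Swap on a Series That Shows No Activity

The source may report more compounds than this note shows. Statements on the series, on what has been measured and on what is new or still open speak of the compounds shown alone.

Compound 2, `O=C(c1cccc(/C=C2\CC(=O)N(c3ccccc3)C2=O)c1)N1CCCC1`, carries a pyrrolidin-1-yl amide on the shared core. In an ADME assay on HCT-116 cells (Homo sapiens) for cytotoxicity, read by MTT assay, with a stated time of 72 h (on this read-out lower numbers stand for stronger inhibition and higher numbers for weaker inhibition), compound 2 gives only a limit, > 100000 nM. Compound 1, `Cc1ccc(NC(=O)c2cccc(/C=C3\CC(=O)N(c4ccccc4)C3=O)c2)cc1`, carries a (4-methylphenyl)amino group on the same carbonyl carbon. In this assay compound 1 likewise gives only a limit, > 100000 nM. The step that the two limits leave unreadable from compound 1 to compound 2 therefore cannot be read, since the limit of > 100000 nM in this assay, at which 2 of the 2 values shown sit, covers both values. Compound 3, `COc1ccc(OC)c(NC(=O)c2cccc(/C=C3\CC(=O)N(c4ccccc4)C3=O)c2)c1`, is the next member: (2,5-dimethoxyphenyl)amino in place of pyrrolidin-1-yl on a carbonyl carbon. Among the compounds with values here, the single measured step bears on this change, as it too exchanges the amide substituent on that carbonyl carbon, yet its size is unknown. Nothing among the numbers shown points to a readable change in this assay, so compound 3 is expected to stay at the limit, with an estimated step of a number no higher from compound 2 to compound 3 (the limit leaves the size open). The estimated value for compound 3 is 100000 nM, with a range from 30000 nM to 300000 nM.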

Compound 3, half-maximal inhibitory concentration: > 100000 nM
Compound 3 was reported as a limit; the forecaster's own chance of this, stated with the estimate: 80%; the middle value lies on the limit itself.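

Compound 3 also gives only a limit, so neither its step from compound 1 nor its step from compound 2 can be read: the limit of > 100000 nM in this assay, at which 3 of the 3 values shown sit. The compounds shown leave open whether any amide substituent on the shared core gives a readable value in this assay.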